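Compound 4: propyl in place of vinyl, expected outcome

A few compounds are considered here, and "the series" means these few. Any claim that something is new, unique, unknown or untested is made for them only; others in the source may bear on it.

Of the compounds shown here, three on a shared core have been measured. In a functional assay on the whole organism (blood, strain albino) with Mus musculus as the target, with stated times of 6 days and 4 h, at a dose of 0.4 mmol/kg by the oral route (a higher number here means more inhibition at the dose given (going by the name of the read-out), a lower number less inhibition), compound 1 `C=CCNC(=S)NS(=O)(=O)c1ccc(-n2nc(C(=O)O)cc2C)cc1` gives -6%. Compound 2 `C=CCNC(=S)NS(=O)(=O)c1ccc(-n2nc(C)cc2C)cc1` gives -1%, and compound 3 `CCCCNC(=O)NS(=O)(=O)c1ccc(-n2nc(C(=O)O)cc2C)cc1` gives 2%. Compound 2 stands second highest of the three, with compound 3 nearest and compound 1 furthest, both gaps within the scatter, so no order among them is claimed.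

Compound 4 `CCCCNC(=S)NS(=O)(=O)c1ccc(-n2nc(C)cc2C)cc1` differs from compound 2 by propyl in place of vinyl on a saturated chain carbon bound to an amide-type nitrogen. Among the measured compounds shown here, no measured step isolates this change. The closest is a number 8 percentage points higher from compound 1 to compound 3 (within the scatter), which alters more than the chain alone; a number 5 percentage points higher from compound 1 to compound 2 (within the scatter) concerns another site. Both are within the scatter, so no step beyond the scatter is expected, giving an expected a number 2 percentage points higher from compound 2 to compound 4 (within the scatter). Compound 4 is thus estimated at 1%, expected between -12% and 14%.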

Compound 4, a percentage reported as inhibition, in the whole organism at one dose (the size of the read-out at that dose, not a potency): 1%
Compound 4: the middle estimate sits on the measured number at the digits printed; measured number inside the range.
By their numbers in this assay, from the lowest: compounds 1, 2, 4 and 3 (each within the scatter of the next).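

In this assay, the saturated chain now has a step of its own, separate from any other change: a number 2 percentage points higher from compound 2 to compound 4 (within the scatter). Allylamino to butylamino at this place, on the methyl-bearing core of compound 2, therefore shifts the read-out by no more than the scatter, whereas the earlier chain step also changed another part of the molecule. No measurement available here bears on why this step is so small.

From the compounds shown here alone, whether a longer chain such as octyl, or a terminal amine on the chain, would give a step beyond the scatter remains open. Also open, going by these compounds, is whether butyl and allyl stay equivalent with a carboxylic acid in place of the methyl on the core.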